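A few compounds are considered here, and "the series" means these few. Any claim that something is new, unique, unknown or untested is made for them only; others in the source may bear on it.

Working notes on the series. For the measured compounds named here, in a functional assay on A549 cells (Homo sapiens) for inhibition, read by MTT assay, with a stated time of 72 h (a higher number here means a weaker inhibitor, a lower number a stronger inhibitor), compound 1 (`Cc1ccc(-n2c(-c3coc4cc(C)c(Cl)cc4c3=O)nc(-c3ccccc3)c2-c2ccccc2)c(C)c1`) reads 6250 nM and compound 2 (`Cc1cc2occ(-c3nc(-c4ccccc4)c(-c4ccccc4)n3-c3ccccc3Cl)c(=O)c2cc1Cl`) reads 12500 nM with the two values within the scatter of each other, so compound 2 stands apart from nothing measured so far.

Compound 3 (`Cc1cc2occ(-c3nc(-c4ccccc4)c(-c4ccccc4)n3-c3cccc([N+](=O)[O-])c3)c(=O)c2cc1Cl`) keeps the shared core and differs from compound 2 by 3-nitrophenyl in place of 2-chlorophenyl on an aromatic nitrogen.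

Going by the values given here, one measured step bears on this change, since it falls on the same aromatic nitrogen. That step is a 2.0-fold higher number from compound 1 to compound 2 (0.30 log units; within the scatter) and it swaps 2,4-dimethylphenyl for 2-chlorophenyl. Among the compounds with values here, it stays within the scatter, but it is a single step, and no measured compound carries 3-nitrophenyl, so the guidance is thin and gives no direction. No shift beyond the scatter is therefore expected in this assay and the range is kept wide. The expected change is small, estimated as a 1.3-fold lower number from compound 2 to compound 3 (0.10 log units; within the scatter) and not beyond the scatter. Compound 3 is estimated at 10000 nM (expected range 3500 nM to 30000 nM).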

Compound 3, half-maximal inhibitory concentration: 6250 nM
Estimate against measurement, compound 3: 1.6-fold (0.20 log units) above, within the range that was stated.
By their numbers in this assay, from the lowest: compounds 1, 3 and 2 (each within the scatter of the next).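

In this assay the aromatic nitrogen now carries a third substituted phenyl group, and 3-nitrophenyl in place of 2-chlorophenyl gives a 2.0-fold lower number from compound 2 to compound 3 (0.30 log units; within the scatter), while 3-nitrophenyl in place of 2,4-dimethylphenyl gives no change at the digits printed from compound 1 to compound 3 (within the scatter). For the compounds shown here, the earlier pair compared only a methyl-bearing group with a chlorine-bearing one, whereas this change brings in a larger group with a double bond outside the aromatic ring and hydrogen-bond acceptors that 2-chlorophenyl lacks, and still no step at this position goes beyond the scatter. Across 2,4-dimethylphenyl, 2-chlorophenyl and 3-nitrophenyl the position therefore shows no order in this assay, and nothing available beyond these numbers bears on why the values sit together.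

Whether any group on this nitrogen can move the number beyond the scatter stays open, since all three groups shown are substituted phenyl rings, leaving an aminophenyl, a carboxyphenyl or a longer alkyl chain untested among these compounds. From the compounds shown here alone, whether the values of this small set carry over to changes elsewhere on the shared core also remains open.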